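The compounds below may be only part of what the source reports. "The series", "measured", "known", "first", "only" and "open" are said of these compounds alone.

In a functional assay on HeLa S3 cells (Homo sapiens) for antiproliferative activity, read by XTT assay, with a stated time of 72 h (a higher number here means a weaker inhibitor, a lower number a stronger inhibitor), compound 3 `Cc1ncnc2c1c(-c1cccs1)cn2[C@@H]1O[C@H](CO)[C@@H](O)[C@H]1O` gives only a limit, > 15000 nM. Compound 4 `Cc1ncnc2c1c(-c1cc3ccccc3o1)cn2[C@@H]1O[C@H](CO)[C@@H](O)[C@H]1O` differs from it by one exchange: 1-benzofuran-2-yl in place of thiophen-2-yl on an aromatic carbon. In words, this is 1-benzofuran-2-yl in place of thiophen-2-yl on an aromatic carbon, with the rest of the structure unchanged.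

For the measured compounds named here, no measured step covers this exchange, so the evidence is indirect and comes from the two compounds that already carry 1-benzofuran-2-yl. Going by the values given here, compound 1 `COc1ncnc2c1c(-c1cc3ccccc3o1)cn2[C@@H]1O[C@H](CO)[C@@H](O)[C@H]1O` gives 9240 nM, the only true number so far. Compound 2 `CNc1ncnc2c1c(-c1cc3ccccc3o1)cn2[C@@H]1O[C@H](CO)[C@@H](O)[C@H]1O` gives only a limit, > 20000 nM. Among the compounds with values here, the single measured step, an at least 2.1-fold higher number from compound 1 to compound 2 (0.33 log units; beyond the scatter), replaces methoxy with methylamino on an aromatic carbon and lies beyond the scatter. It shows that 1-benzofuran-2-yl alone does not settle the outcome in this assay, and it gives no size for the exchange at hand.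

With compound 1 at 9240 nM as the nearest anchor, only a small shift towards a lower number is expected, and it may not clear the scatter. The expected step is an at least 1.6-fold lower number from compound 3 to compound 4 (0.22 log units; that floor lies within the scatter). Compound 4 is estimated at 9000 nM, with an expected range from 3000 nM to 20000 nM. A reading that returns only a limit remains quite possible.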

Compound 4, half-maximal inhibitory concentration: > 20000 nM
Compound 4: only a limit was reported (the forecaster's own chance of this, stated with the estimate: 40%); middle value at least 2.2-fold (0.34 log units) away from the limit.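

With 1-benzofuran-2-yl held constant, methyl in place of methoxy on an aromatic carbon gives an at least 2.1-fold higher number from compound 1 to compound 4 (0.33 log units; beyond the scatter) in this assay, and this is the second exchange away from methoxy with a step beyond the scatter, after methylamino in an at least 2.1-fold higher number from compound 1 to compound 2 (0.33 log units; beyond the scatter). Compound 4 gives only a limit, > 20000 nM. The steps from compound 3 to compound 4 and from compound 2 to compound 4 cannot be read, because they end on limits such as this one: the limit of > 20000 nM in this assay, at which 2 of the 4 values shown sit.

Whether 1-benzofuran-2-yl reads differently from thiophen-2-yl in this assay remains open: no pair shown carries that exchange with a true number at both ends. Also open, on these data alone, is how a primary amine, dimethylamino or a longer alkoxy chain such as ethoxy, set on the carbon that bears methoxy in compound 1, would compare with methoxy, and whether any of these would give a true number rather than a limit.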